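Bromo in place of cyclohexylmethoxy on the shared core

A few compounds are considered here, and "the series" means these few. Any claim that something is new, unique, unknown or untested is made for them only; others in the source may bear on it.

Compound 1 `NC(=O)N(O)CC1=Cc2cc(OCc3ccccc3)ccc2OC1`: 380 nM in an assay (Cavia porcellus) for inhibition of Polyunsaturated fatty acid 5-lipoxygenase (Homo sapiens); a lower number here means a stronger inhibitor, a higher number a weaker inhibitor
Compound 2 `NC(=O)N(O)CC1=Cc2cc(OCC3CCCCC3)ccc2OC1`: 1390 nM

Compound 2 gives the highest of the two numbers in this assay, with a 3.7-fold higher number from compound 1 to compound 2 (0.56 log units; beyond the scatter). Compound 3 `NC(=O)N(O)CC1=Cc2cc(Br)ccc2OC1` carries bromo in place of cyclohexylmethoxy on an aromatic carbon. For the measured compounds named here, no measured step swaps an ether for a halogen, so the single step from compound 1 to compound 2 bears on it only loosely. The expected step for compound 3 is a 1.6-fold higher number from compound 2 to compound 3 (0.20 log units; within the scatter), a small rise. Compound 3 is estimated at 2200 nM, between 500 nM and 9000 nM.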

Compound 3, half-maximal inhibitory concentration: 1400 nM
Beside the measured number, compound 3's estimate is 1.6-fold (0.20 log units) above it; the range from low to high includes it.
By their numbers in this assay, from the lowest: compound 1; then compounds 2 and 3 (each within the scatter of the next).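

Replacing cyclohexylmethoxy with bromo on this aromatic carbon leaves this assay unmoved beyond the scatter (a 1.0-fold higher number from compound 2 to compound 3 (0.00 log units; within the scatter)), so a lone bromine and a ringed ether of 8 heavy atoms cannot be told apart here. Among these three compounds only benzyloxy stands apart, as bromo in its place gives a clear step (a 3.7-fold higher number from compound 1 to compound 3 (0.57 log units; beyond the scatter)). No available evidence accounts for either step.

On these data alone, whether an amine or a carboxylic acid on this carbon would fall with compound 1 or with compound 2 and compound 3 remains open. So does the effect of a phenethoxy group in place of benzyloxy.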